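The source may report more compounds than this note shows. Statements on the series, on what has been measured and on what is new or still open speak of the compounds shown alone.

In a functional assay on HT-29 cells (Homo sapiens) for inhibition, read by CCK-8 assay, with a stated time of 24 h (on this read-out higher numbers stand for weaker inhibition and lower numbers for stronger inhibition), compound 1 `O=C1Nc2ccccc2/C1=C/c1ccc(-c2cn(-c3cccc(Cl)c3)nn2)cc1` gives > 20000 nM as its reading, which is a limit of the assay and not a number. Within the data shown here, compound 2 `Cc1ccc(-n2cc(-c3ccc(/C=C4\C(=O)Nc5ccc(F)cc54)cc3)nn2)cc1` gives 3980 nM in this assay and thus holds the only actual number so far. Compound 3 `O=C1Nc2ccc(F)cc2/C1=C/c1ccc(-c2cn(-c3ccc(Cl)c(C(F)(F)F)c3)nn2)cc1` has not yet been measured in this assay and shares the core of compound 2. The structural change is summed up by 4-chloro-3-(trifluoromethyl)phenyl in place of 4-methylphenyl on an aromatic nitrogen and in words it is 4-chloro-3-(trifluoromethyl)phenyl in place of 4-methylphenyl on an aromatic nitrogen of the five-membered aromatic ring with 3 nitrogen. Among the measured compounds shown here, no measured step shows what a change at this place does. The expectation therefore starts from compound 2 at 3980 nM alone and carries wide uncertainty. A modest move toward stronger inhibition in this assay is expected, with a 2.0-fold lower number from compound 2 to compound 3 (0.30 log units; within the scatter) estimated to lie near the edge of the usual scatter and a result within that scatter quite possible. For compound 3 the estimate is 2000 nM and the expected range runs from 600 nM to 9000 nM on this read-out.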

Compound 3, half-maximal inhibitory concentration: 16500 nM
Estimate against measurement, compound 3: 8.3-fold (0.92 log units) below; measured number outside the range, above it.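

In this assay, the aryl group on the aromatic nitrogen of the five-membered aromatic ring with 3 nitrogen now has its first measured step: 4-chloro-3-(trifluoromethyl)phenyl in place of 4-methylphenyl gives a 4.1-fold higher number from compound 2 to compound 3 (0.62 log units; beyond the scatter). The reading at this position therefore responds to the group it carries, and on the shared core this exchange of 4-methylphenyl, with 7 heavy atoms, for a group with 11 heavy atoms goes toward weaker inhibition. This leaves little room on the read-out in that direction: the limit of > 20000 nM in this assay, at which 1 of the 3 values shown sits.

The step cannot separate the chlorine from the trifluoromethyl group, as both enter together, so a phenyl ring carrying only one of them would be needed to assign the loss to either. Also open, as far as these compounds go, is how this position responds to groups of a different kind, such as an amine or a carboxylic acid on the phenyl ring, or a longer alkyl chain in place of the ring, and whether any of them gives stronger inhibition than the 4-methylphenyl group.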